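The source may hold more compounds than are shown below. What is called first, only, known or untested is meant among the compounds shown, and "the series" means these compounds.

Measured compounds:
compound 1, `CC(=O)OCCc1ccc(O)c(O)c1`, > 50000 nM
compound 2, `CCCC(=O)OCCc1ccc(O)c(O)c1`, 71500 nM
compound 3, `CCCCCCCCCC(=O)OCCc1ccc(O)cc1`, 172000 nM

All three were run in a toxicity assay on MRC5 cells (Homo sapiens) for inhibition, read by MTT assay, with a stated time of 72 h; a lower number here means a stronger inhibitor, a higher number a weaker inhibitor. For compound 1 the entry > 50000 nM is a limit of the assay, not a number. Compound 2 gives 71500 nM in this assay, and compound 3 gives 172000 nM, the highest number of the two with a reading. The change from compound 2 to compound 1 is hydrogen in place of ethyl on a saturated chain carbon bound to a carbonyl carbon; the step that the limit leaves unreadable from compound 2 to compound 1 cannot be read as a size because of the limit of > 50000 nM in this assay, at which 1 of the 3 values shown sits. The difference between the cores of compound 3 and compound 2 is not broken down here.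

Compound 4, `CCCCCCCC(=O)OCCc1ccc(O)cc1`, is not yet measured in this assay. The change from compound 3 to compound 4 is hydrogen in place of ethyl on a saturated chain carbon, seven bonds along the chain from a carbonyl carbon, the same kind of change as that from compound 2 to compound 1 but placed seven bonds along the chain from the carbonyl carbon rather than bound to it. The measured instance gives no readable size, so for compound 4 a small step is expected, with a 1.3-fold lower number from compound 3 to compound 4 (0.12 log units; within the scatter) as the estimate, resting on the reading of compound 3 at 172000 nM. Compound 4 is expected to give about 130000 nM, between 55000 nM and 300000 nM.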

Compound 4, half-maximal inhibitory concentration: 133000 nM
Beside the measured number, compound 4's estimate is 1.0-fold (0.01 log units) below it; the measured number falls inside the stated range.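

In this assay, hydrogen in place of ethyl on a saturated chain carbon, seven bonds along the chain from a carbonyl carbon, gives a 1.3-fold lower number from compound 3 to compound 4 (0.11 log units; within the scatter), so on the core of compound 3 this change has no effect that can be told from the scatter. Compound 1 stands at a limit, not a number, so the same kind of change from compound 2 to compound 1, on a saturated chain carbon bound to a carbonyl carbon, cannot be read as a size: the limit of > 50000 nM in this assay, at which 1 of the 4 values shown sits. With one readable instance, on one core and at one place in the chain, the series neither supports nor contradicts carrying this change to another core.

The compounds shown leave open how this assay responds to a longer chain on the core of compound 3, or to an amine or a carboxylic acid at the chain end. No pair shown isolates the difference between the two cores at a fixed chain.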